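Extending the bromoalkoxy chain on the trimethoxystyryl core

The source may report more compounds than this note shows. Statements on the series, on what has been measured and on what is new or still open speak of the compounds shown alone.

Measured compounds:
compound 1, `COc1ccc(/C=C/c2cc(/C=C/c3ccc(OC)cc3)nc(OCCCCCBr)n2)cc1`: in a functional assay on A549 cells (Homo sapiens) for cytotoxicity, read by fluorescence and resazurin assay, with a stated time of 48 h (a higher number here means a weaker inhibitor, a lower number a stronger inhibitor), compound 1 gives > 20000 nM, a limit of the assay.
compound 2, `COc1cc(/C=C/c2cc(/C=C/c3cc(OC)c(OC)c(OC)c3)nc(OCCCCBr)n2)cc(OC)c1OC`: in this assay compound 2 gives > 20000 nM, a limit of the assay.
compound 3, `COc1ccc(/C=C/c2cc(/C=C/c3ccc(OC)cc3)nc(OCCCCBr)n2)cc1`: in this assay compound 3 gives > 20000 nM, a limit of the assay.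

All three results sit at the limit of > 20000 nM in this assay, at which 3 of the 3 values shown sit, so none of these compounds shows a readable half-maximal inhibitory concentration in this assay. Compound 2 therefore stands only at a limit, with no number that would place it against the others.

The unmeasured compound 4, `COc1cc(/C=C/c2cc(/C=C/c3cc(OC)c(OC)c(OC)c3)nc(OCCCCCBr)n2)cc(OC)c1OC`, differs from compound 2 by bromomethyl in place of bromo on a saturated chain carbon, four bonds along the chain from an oxygen on an aromatic ring. Among the measured compounds shown here, the one measured step that matches this change is a step that the two limits leave unreadable from compound 1 to compound 3, which runs in the opposite direction and is itself unreadable, since both ends of it are limits. For the measured compounds named here, there is thus no measured step of known size that bears on the change from compound 2 to compound 4.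

On this basis the expectation for compound 4 is a result at the same limit, that is a step that the limit leaves unreadable from compound 2 to compound 4 in this assay, which is no step beyond the scatter. The estimate for compound 4 is 30000 nM, with an expected range from 15000 nM to 100000 nM.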

Compound 4, half-maximal inhibitory concentration: > 20000 nM
Compound 4 gave a limit, no number (the forecaster's own chance of this, stated with the estimate: 85%); the middle value lies beyond the limit too.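

In this assay compound 4, like compound 2, gives only a limit, so no step can be read from compound 2 to compound 4, and the same holds for compound 1 and compound 3: the limit of > 20000 nM in this assay, at which 4 of the 4 values shown sit.

Whether any of these compounds has a readable half-maximal inhibitory concentration in this assay stays open, and with it whether the bromoalkoxy chain has any bearing on that value.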